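Aryl swap on the thiosemicarbazone arm of compound 2

This account rests on a few compounds, and the source may have more. Where it says the series, first, only, none or still open, it means among the compounds named here.

Among the measured compounds shown here, compound 2 `Cc1ccc2c(c1)/C(=N/NC(=S)N/N=C/c1ccccn1)C(=O)N2` is the only member of this pair with a number: in a functional assay on COS-7 cells (Chlorocebus aethiops) for inhibition, read by MTT assay (on this read-out lower numbers stand for stronger inhibition and higher numbers for weaker inhibition), compound 2 gives 2120 nM. Compound 1 `Cc1ccc2c(c1)/C(=N/NC(=S)N/N=C/c1ccccc1Br)C(=O)N2` reaches only a limit in this assay, > 50000 nM; the limit of > 50000 nM in this assay, at which 1 of the 2 values shown sits, is a limit of the assay and not a number. For the measured compounds named here, the one measured step, an at least 23-fold lower number from compound 1 to compound 2 (1.37 log units; beyond the scatter), runs from a halogenated phenyl to pyridin-2-yl and is large.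

Compound 3 `Cc1ccc2c(c1)/C(=N/NC(=S)N/N=C/c1c(F)cccc1Cl)C(=O)N2` carries 2-chloro-6-fluorophenyl in place of pyridin-2-yl on a carbon with a double bond to nitrogen. This reverses the direction of the measured step: a halogenated phenyl again replaces pyridin-2-yl on the carbon with a double bond to nitrogen, so the expectation rests on an at least 23-fold lower number from compound 1 to compound 2 (1.37 log units; beyond the scatter) read backwards, with a rise in the number. The halogen pattern differs from that of compound 1, so the size is uncertain.

Compound 3 is estimated at 25000 nM in this assay, between 6000 nM and 50000 nM. The expected step of a 12-fold higher number from compound 2 to compound 3 (1.07 log units; beyond the scatter) is thus large and upward, with a fair chance that only a limit is reported.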

Compound 3, half-maximal inhibitory concentration: 2190 nM
Estimate against measurement, compound 3: 11-fold (1.06 log units) above; the measured number lies below the stated range.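

Working note on the arm: pyridin-2-yl is not needed at this position in this assay, where a ring of carbon only gives a matching result, a 1.0-fold higher number from compound 2 to compound 3 (0.01 log units; within the scatter). A halogenated phenyl on the carbon with a double bond to nitrogen is therefore not poor as a class, and the pattern of halogens separates the two phenyl compounds, an at least 22-fold lower number from compound 1 to compound 3 (1.35 log units; beyond the scatter). The value of compound 1 is a limit and not a number, so the size of that step stays open: the limit of > 50000 nM in this assay, at which 1 of the 3 values shown sits.

The compounds shown do not separate the bromine from the chlorine and fluorine, nor the single substituent from the pair. Going by these compounds, how an unsubstituted phenyl, or a phenyl bearing a methoxy group or an amine, would read in this assay also remains open.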